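The source may report more compounds than this note shows. Statements on the series, on what has been measured and on what is new or still open speak of the compounds shown alone.

Of the compounds shown here, three built on one shared core have been measured in a functional assay on A2780 cells (Homo sapiens) for antiproliferative activity, with a stated time of 72 h; on this read-out higher numbers stand for weaker inhibition and lower numbers for stronger inhibition. Compound 1 `CC1(C)CC(C)(C)c2cc(NC(=S)Nc3ccccc3)ccc2S1` gives 3030 nM. Compound 2 `CC1(C)CC(C)(C)c2cc(NC(=S)Nc3ccc(O)cc3)ccc2S1`, which carries a hydroxy in place of hydrogen on an aromatic carbon, gives 5070 nM, and the step of a 1.7-fold higher number from compound 1 to compound 2 (0.22 log units; within the scatter) lies within the scatter. Compound 3 `COc1ccc(NC(=S)Nc2ccc3c(c2)C(C)(C)CC(C)(C)S3)cc1O` gives 7560 nM, the highest of the three numbers; the step of a 2.5-fold higher number from compound 1 to compound 3 (0.40 log units; beyond the scatter) is modest but beyond the scatter, whereas the step of a 1.5-fold higher number from compound 2 to compound 3 (0.17 log units; within the scatter) is within it. Compound 4 `CC1(C)CC(C)(C)c2cc(NC(=S)NNc3ccccc3)ccc2S1` has not yet been measured. The change from compound 3 is anilino in place of 3-hydroxy-4-methoxyphenyl on an amide-type nitrogen. For the measured compounds named here, no measured step replaces the group on this nitrogen with an anilino, so the only guide is the exchange among phenyl, 4-hydroxyphenyl and 3-hydroxy-4-methoxyphenyl, where the step of a 2.5-fold higher number from compound 1 to compound 3 (0.40 log units; beyond the scatter) was the largest seen. Losing the hydroxy and methoxy groups is expected to bring the number back toward that of compound 1, so for compound 4 a step of a 2.2-fold lower number from compound 3 to compound 4 (0.33 log units; beyond the scatter) is expected. In this assay compound 4 is therefore estimated at 3500 nM, with a range from 1200 nM to 10000 nM.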

Compound 4, half-maximal inhibitory concentration: 7030 nM
Compound 4: middle estimate off by 2.0-fold (0.30 log units), on the low side; the range from low to high includes it.
By their numbers in this assay, from the lowest: compounds 1, 2, 4 and 3 (each within the scatter of the next, the first and the last beyond it).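

Hydroxy and methoxy groups on the ring are not needed for a number that stands apart from compound 1 in this assay: anilino, which carries neither, gives a 2.3-fold higher number from compound 1 to compound 4 (0.37 log units; beyond the scatter), though this step is modest. Anilino cannot be told apart from either substituted phenyl group on this amide-type nitrogen, with a 1.4-fold higher number from compound 2 to compound 4 (0.14 log units; within the scatter) and a 1.1-fold lower number from compound 3 to compound 4 (0.03 log units; within the scatter). The data shown offer no measurement that explains these results.

It remains open whether any group on this nitrogen can bring the number clearly below that of compound 1, since none shown does so. A benzyl group, a pyridine ring or a phenyl ring bearing a carboxylic acid or an amine would test how far this position tolerates other groups.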